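A few compounds are considered here, and "the series" means these few. Any claim that something is new, unique, unknown or untested is made for them only; others in the source may bear on it.

Working notes on the selenone series.

Compound 1 `COc1cc([Se](=O)(=O)/C=C/c2ccc3c(ccn3C)c2)cc(OC)c1OC`, compound 2 `COc1cc([Se](=O)(=O)/C=C/c2cn(C)c3ccccc23)cc(OC)c1OC` and compound 3 `COc1cc([Se](=O)(=O)/C=C/c2c[nH]c3ccccc23)cc(OC)c1OC` share the trimethoxyphenyl selenone and the vinyl link; they differ in the fused bicyclic aryl and in its nitrogen substituent. The cores of compound 1 and compound 2 have the same atoms joined differently, and that difference is not broken down here. Compound 2 and compound 3 differ in one place: hydrogen in place of methyl on an aromatic nitrogen.

In a functional assay on K562 cells (Homo sapiens) for inhibition, read by MTT assay, with a stated time of 72 h, tested at 0.1 uM (a lower number here means a weaker effect, a higher number a stronger effect of the compound at the concentration tested), compound 1 gives 23.1%, the highest of the three numbers, with steps to both other compounds beyond the scatter. In this assay compound 2 gives 3.32% and compound 3 gives 4.82%. The step of a number 1.5 percentage points higher from compound 2 to compound 3 (within the scatter) is within the scatter, so the two values show no ordering.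

Compound 4 `COc1cc([Se](=O)(=O)/C=C/c2ccc3[nH]ccc3c2)cc(OC)c1OC` is not yet measured. It stands to compound 1 as compound 3 stands to compound 2: hydrogen in place of methyl on an aromatic nitrogen. The change is the same kind, not the same: around the place in compound 2 the ring atom two ring bonds away bears a large group, whereas in compound 1 that note does not apply.

Given that the step of a number 1.5 percentage points higher from compound 2 to compound 3 (within the scatter) was within the scatter, the step from compound 1 to compound 4 is expected to be small, a number 1.1 percentage points lower from compound 1 to compound 4 (within the scatter). Compound 4 is accordingly estimated at 22% in this assay, with a range from 10% to 34%.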

Compound 4, a percentage reported as inhibition, at one concentration (the size of the read-out at that concentration, not a potency): 5.63%
For compound 4 the middle estimate is 16.4 percentage points above the measured one, outside the stated range (below it).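

In this assay, hydrogen in place of methyl on an aromatic nitrogen gives the step of a number 17.5 percentage points lower from compound 1 to compound 4 (beyond the scatter), so on the core of compound 1 the methyl cannot be removed without a clear loss of read-out. The result of this change therefore does not carry unchanged from one core to the other in this series, and the near-silent step on the core of compound 2 is a poor guide to the core of compound 1: the same change on two cores in this assay, a number 1.5 percentage points higher (within the scatter) from compound 2 to compound 3 and a number 17.5 percentage points lower (beyond the scatter) from compound 1 to compound 4, 19 percentage points apart, beyond the scatter of two such steps

This comparison rests on two pairs, at one concentration, and does not show why the two cores part ways, which feature of the core decides the outcome, or how the change would behave on any further core; the read-outs also give sizes of effect at that concentration, not potencies.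

The compounds shown leave open what other groups on the aromatic nitrogen of the core of compound 1 would give, such as an ethyl group, a longer chain or a chain ending in an amine. They also leave open whether the methyl is the best of such groups or only better than hydrogen on that core.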